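The compounds below may be only part of what the source reports. "The series", "measured", "known", "first", "only" and "open" are said of these compounds alone.

In a functional assay on SMA cells (Homo sapiens) for inhibition, read by MTT assay, with a stated time of 72 h (a higher number here means a weaker inhibitor of growth, a lower number a stronger inhibitor of growth), compound 3 `N#C/C(=C\c1ccc(Cl)cc1)C(=O)NCc1ccc(Cl)c(Cl)c1` gives 33000 nM, the lower of the two numbers shown, though compound 2 `N#C/C(=C\c1ccco1)C(=O)NCc1ccc(Cl)c(Cl)c1` stands within the scatter of it at 38000 nM. Compound 1 `N#C/C(=C\c1ccc[nH]1)C(=O)NCc1ccc(Cl)c(Cl)c1` reaches only the limit of > 50000 nM in this assay, at which 1 of the 3 values shown sits, and is recorded as > 50000 nM, a limit and not a number. The steps among these three are small: an at least 1.3-fold lower number from compound 1 to compound 2 (0.11 log units; that floor lies within the scatter), an at least 1.5-fold lower number from compound 1 to compound 3 (0.18 log units; that floor lies within the scatter) and a 1.2-fold lower number from compound 2 to compound 3 (0.06 log units; within the scatter), each within the scatter or with a floor inside it. Compound 4 `COc1ccc(/C=C(\C#N)C(=O)NCc2ccc(Cl)c(Cl)c2)cc1` differs from compound 3 by methoxy in place of chloro on an aromatic carbon, para to a large group. Within the data shown here, no measured step swaps one substituent for another on that ring; the measured steps exchange the whole group on the double-bonded chain carbon and none of them moves the number beyond the scatter. On that basis the step expected for compound 4 is a 1.2-fold higher number from compound 3 to compound 4 (0.08 log units; within the scatter), essentially no change beyond the scatter. Compound 4 is therefore estimated at 40000 nM, with a range from 15000 nM to 100000 nM, and its upper end could appear as a limit of the assay.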

Compound 4, concentration for 50% growth inhibition: > 100000 nM
Compound 4: no number, only a limit (the forecaster's own chance of this, stated with the estimate: 35%); middle value at least 2.5-fold (0.39 log units) away from the limit.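

In this assay, compound 4 is recorded as a limit and not a number: the limit of > 100000 nM in this assay, at which 1 of the 4 values shown sits.

The earlier steps shown here all stayed within the scatter or had a floor inside it, whereas methoxy in place of chloro on an aromatic carbon, para to a large group, gives an at least 3.0-fold higher number from compound 3 to compound 4 (0.48 log units; beyond the scatter), so a change on this ring alone can move the number beyond the scatter. Exchanging the whole group on the double-bonded chain carbon also passes the scatter, with an at least 2.6-fold higher number from compound 2 to compound 4 (0.42 log units; beyond the scatter), while the step from compound 1 to compound 4 cannot be read.

From the compounds shown here alone, the true size of the change at this position remains open. Also open, going by these compounds, is whether a hydroxy group or an amine at the same place would track with compound 3 or with compound 4.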